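Shortening an Acyl Chain on a Glutamate Receptor Modulator

This account rests on a few compounds, and the source may have more. Where it says the series, first, only, none or still open, it means among the compounds named here.

Compound 1 `CCCC(=O)c1ccc(OCCCCOc2ccc(C(=O)O)cc2C)c(C)c1O`: 79.3%
Compound 2 `Cc1c(OCCCCOc2ccc(F)c(C(=O)O)c2)ccc(C(=O)CC2CCCC2)c1C`: 14.6%

For the measured compounds named here, in an assay on HEK293 cells for positive allosteric modulation of metabotropic glutamate receptor 2 (Rattus norvegicus), read by thallium flux, with a stated time of 2.5 min (on this read-out lower numbers stand for smaller maximal responses and higher numbers for larger maximal responses), compound 1 gives 79.3%, the highest of the two numbers so far. Compound 2 gives 14.6% in this assay, a gap that lies beyond the usual scatter; since these two compounds differ in several places at once, no single change can be credited with it. Compound 3 `CC(=O)c1ccc(OCCCCOc2ccc(C(=O)O)cc2C)c(C)c1O` has not yet been measured. It differs from compound 1 in one place: hydrogen in place of ethyl on a saturated chain carbon bound to a carbonyl carbon. Going by the values given here, no single-change step between measured compounds is available, so the expectation rests on compound 1 alone, and the smaller chain is an untested change. The step is expected to run downward, a number 29.3 percentage points lower from compound 1 to compound 3 (beyond the scatter), a drop that would probably reach beyond the usual scatter, though with wide uncertainty. Compound 3 is estimated at 50%, within a range from 15% to 85%.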

Compound 3, largest response reached (reported as percent of maximum), in percent of the reference or control that the assay uses: 83.1%
The estimate for compound 3 lay 33.1 percentage points below the measured number; the measured number falls inside the stated range.
By their numbers in this assay, from the lowest: compound 2; then compounds 1 and 3 (each within the scatter of the next).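

In this assay, putting hydrogen in place of ethyl on the saturated chain carbon bound to a carbonyl carbon gives a number 3.8 percentage points higher from compound 1 to compound 3 (within the scatter). On this core, then, the ethyl is not needed to keep the maximal response, and the propylcarbonyl and acetyl forms cannot be told apart on this read-out. Nothing measured here speaks to the reason for this match.

The compounds shown leave open whether a longer chain at this place, or an amine in place of the ethyl, would also leave the maximal response in the same range. They also leave open what part the acyl group plays in the low number of compound 2, which differs from compound 1 in several places at once.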